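Chloro Substitution on the Weakest Member of the Pyrazoline Series

The compounds below may be only part of what the source reports. "The series", "measured", "known", "first", "only" and "open" are said of these compounds alone.

Compound 1 `Cn1c(N2N=C(c3ccccc3)CC2c2ccccc2)nc(-c2ccccc2)c(C#N)c1=O` gives 52900 nM in a functional assay on A549 cells (Homo sapiens) for antiproliferative activity, with a stated time of 72 h; a lower number here means a stronger inhibitor, a higher number a weaker inhibitor. Compound 2 `COc1ccc(C2CC(c3ccccc3)=NN2c2nc(-c3ccccc3)c(C#N)c(=O)n2C)cc1` gives 1760 nM, a step of a 30-fold lower number from compound 1 to compound 2 (1.48 log units; beyond the scatter). Compound 3 `COc1ccc(C2CC(c3ccc(Cl)cc3)=NN2c2nc(-c3ccccc3)c(C#N)c(=O)n2C)cc1` gives 6070 nM, a step of a 3.4-fold higher number from compound 2 to compound 3 (0.54 log units; beyond the scatter), the change being (chloro in place of hydrogen on an aromatic carbon). Compound 4 `Cn1c(N2N=C(c3ccccc3)CC2c2ccccc2)nc(-c2ccc(Cl)cc2)c(C#N)c1=O` is not yet measured; it differs from compound 1 by chloro in place of hydrogen on an aromatic carbon, the same change as from compound 2 to compound 3, at a place described in identical words. The cores of compound 1 and compound 2 differ by hydrogen in place of methoxy on an aromatic carbon. For compound 4 a step of a 2.8-fold higher number from compound 1 to compound 4 (0.45 log units; beyond the scatter) is expected in this assay, resting on the change seen from compound 2 to compound 3, where the step was a 3.4-fold higher number from compound 2 to compound 3 (0.54 log units; beyond the scatter). Compound 4 is accordingly estimated at 150000 nM, between 45000 nM and 500000 nM.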

Compound 4, half-maximal inhibitory concentration: 28100 nM
Compound 4: the middle estimate sits 5.3-fold (0.73 log units) above what was measured; measured number outside the range, below it.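

The step on the core of compound 1 is a 1.9-fold lower number from compound 1 to compound 4 (0.27 log units; within the scatter), so in this assay compound 4 cannot be told apart from compound 1. Chloro in place of hydrogen therefore does not carry over as a fixed step between these two cores: the same change on two cores in this assay, a 3.4-fold higher number (0.54 log units; beyond the scatter) from compound 2 to compound 3 and a 1.9-fold lower number (0.27 log units; within the scatter) from compound 1 to compound 4, 6.5-fold (0.81 log units) apart, beyond the scatter of two such steps. This does not show why the steps differ, and one pair per core gives no rule; the structures also place the chloro on different phenyl rings in compound 3 and compound 4, so the effects of core and ring cannot be separated.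

Open, going by these compounds, is whether the 4-chlorophenyl of compound 4 would behave the same on the methoxy-bearing core of compound 2. Also open, on these data alone, is whether an amine or a carboxylic acid in place of that chloro would follow either step.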